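The compounds below may be only part of what the source reports. "The series", "measured", "known", "first", "only" and "open" are said of these compounds alone.

For the measured compounds named here, compound 2 `COc1cc(-c2cc(/C=C/C(=O)c3ccc(Cl)c(Cl)c3)[nH]n2)cc(OC)c1OC` is one of two compounds measured in a functional assay on A549 cells (Homo sapiens) for inhibition, read by sulforhodamine B assay, with a stated time of 48 h; a higher number here means a weaker inhibitor of growth, a lower number a stronger inhibitor of growth. In this assay compound 2 gives 18700 nM, the higher of the two numbers. The other compound, compound 1 `COc1ccc(-c2cc(/C=C/C(=O)c3ccc(N)cc3)[nH]n2)cc1`, gives in this assay 2550 nM, so of these two compound 2 is the weaker inhibitor of growth.

Compound 3 `COc1ccc(C(=O)/C=C/c2cc(-c3cc(OC)c(OC)c(OC)c3)n[nH]2)cc1` has not yet been measured. It differs from compound 2 in one place: 4-methoxyphenyl in place of 3,4-dichlorophenyl on a carbonyl carbon. Compound 2 and compound 3 share the same core, and the group on the other side of that core is unchanged. Going by the values given here, no measured pair shows this exact exchange, so the size of the step is uncertain. Among the compounds with values here, the only other compound with an oxygen-bearing or nitrogen-bearing group on the carbonyl side is compound 1, which gives the lower number 2550 nM, so a modest move toward a lower number is expected, but it may still fall within the scatter. Compound 3 is estimated at 9000 nM, with a range from 3000 nM to 30000 nM, meaning an expected step of a 2.1-fold lower number from compound 2 to compound 3 (0.32 log units; beyond the scatter).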

Compound 3, concentration for 50% growth inhibition: 2270 nM
The estimate for compound 3 lay 4.0-fold (0.60 log units) above the measured number, and the stated range ends above it.
By their numbers in this assay, from the lowest: compounds 3 and 1 (each within the scatter of the next); then compound 2.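

In this assay the group on the carbonyl carbon clearly matters: with the rest of the molecule unchanged, 4-methoxyphenyl in place of 3,4-dichlorophenyl gives an 8.2-fold lower number from compound 2 to compound 3 (0.92 log units; beyond the scatter) and so makes a stronger inhibitor of growth. For the compounds shown here, this is the first pair that differs in one place, so this change can now be read on its own, and the step lies beyond the usual scatter of the assay. Nothing measured here accounts for the size of this step.

A single exchange cannot separate losing the two chlorines from gaining the methoxy group, and an unsubstituted phenyl on the carbonyl carbon would help to tell these apart. As far as these compounds go, it also remains open how a 4-hydroxyphenyl or a carboxylic acid on that ring would behave.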